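Cyclopropyl for isopropyl on the ring amide nitrogen

The compounds below may be only part of what the source reports. "The series", "measured", "known", "first", "only" and "open" are said of these compounds alone.

Measured so far in a functional assay on HepG2 cells (Homo sapiens) for antiproliferative activity, read by MTT assay, with a stated time of 72 h; on this read-out lower numbers stand for stronger inhibition and higher numbers for weaker inhibition:
- compound 1 `O=C1COc2ccc(-c3cnc(Cl)c(NS(=O)(=O)c4ccc(F)cc4)c3)cc2N1c1ccc(F)cc1`: > 40000 nM
- compound 2 `CC(C)N1C(=O)COc2ccc(-c3cccc(NS(=O)(=O)c4ccc(F)cc4)c3)cc21`: > 40000 nM
- compound 3 `Cc1ccc(N2C(=O)COc3ccc(-c4cnc5ccccc5c4)cc32)cc1`: > 40000 nM

Each entry is a limit of the assay and not a number.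

Compound 2 stands at > 40000 nM, which is a limit only. Going by the values given here, the other two compounds give no firmer footing, and the series so far amounts to the limit of > 40000 nM in this assay, at which 3 of the 3 values shown sit. Among the compounds with values here, no measured number is available in this assay, and no step between measured compounds exists to serve as a guide.

Compound 4 `O=C1COc2ccc(-c3cccc(NS(=O)(=O)c4ccc(F)cc4)c3)cc2N1C1CC1` differs from compound 2 in one place: cyclopropyl in place of isopropyl on an amide-type nitrogen in a ring. This puts cyclopropyl in place of isopropyl on an amide-type nitrogen in a ring.

Because compound 2 gives > 40000 nM as a limit, no step beyond the usual scatter is expected, in either direction. The expected step is a number no higher from compound 2 to compound 4 (the limit leaves the size open). For compound 4 the estimate is 40000 nM, with an expected range of 12000 nM to 60000 nM.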

Compound 4, half-maximal inhibitory concentration: > 40000 nM
Compound 4 was reported as a limit (the forecaster's own chance of this, stated with the estimate: 75%); the middle value sits exactly at the limit.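

No step can be read between compound 2 and compound 4 in this assay, because both values are limits of the assay: the limit of > 40000 nM in this assay, at which 4 of the 4 values shown sit.

The compounds shown leave open how cyclopropyl and isopropyl on the amide-type nitrogen compare, and which structural change would give a measurable value in this assay.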